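Aminopyrrolopyrimidine nitriles: amino replacing methylpyrrolidinyl

The source may report more compounds than this note shows. Statements on the series, on what has been measured and on what is new or still open speak of the compounds shown alone.

Measured so far:
compound 1, `Cn1c(NCc2ccccc2)c(C#N)c2c(N)ncnc21`, 243 nM
compound 2, `C[C@H]1CCCN1c1c(C#N)c2c(N)ncnc2n1C`, 212 nM

Both numbers come from an assay on isolated protein for binding affinity to Leucine-rich repeat serine/threonine-protein kinase 2 variant G2019S (Homo sapiens), read by TR-FRET and LanthaScreen, with a stated time of 2 h; on this read-out higher numbers stand for weaker inhibition and lower numbers for stronger inhibition. In this assay compound 2 gives 212 nM and compound 1 gives 243 nM; the two lie within the scatter of each other, so compound 2 cannot be set apart from compound 1 on these data. For the measured compounds named here, no single-change step between measured compounds exists.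

Compound 3, `Cn1c(N)c(C#N)c2c(N)ncnc21`, differs from compound 2 by amino in place of 2-methylpyrrolidin-1-yl on an aromatic carbon. The two measured compounds both carry a larger group at this carbon and sit close together, which gives no direct guide for the much smaller amino. A loss of binding beyond the scatter is expected, with compound 3 estimated at 1000 nM, range 300 nM to 4000 nM, which means an expected step of a 4.7-fold higher number from compound 2 to compound 3 (0.67 log units; beyond the scatter).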

Compound 3, inhibition constant: 589 nM
Compound 3: the middle estimate sits 1.7-fold (0.23 log units) above what was measured; measured number inside the range.
By their numbers in this assay, from the lowest: compounds 2 and 1 (each within the scatter of the next); then compound 3.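

In this assay, cutting the group on this aromatic carbon back to amino weakens binding in both available comparisons: loss of 2-methylpyrrolidin-1-yl (a 2.8-fold higher number from compound 2 to compound 3 (0.44 log units; beyond the scatter)) and loss of the benzyl on the nitrogen (a 2.4-fold higher number from compound 1 to compound 3 (0.38 log units; beyond the scatter)). Both steps are modest though beyond the scatter, so neither the five-membered non-aromatic ring nor the benzyl is essential for measurable binding, and the small amino of compound 3 retains much of it. No data here bear on the reason for the difference.

Going by these compounds, whether a small substituted amine such as methylamino or dimethylamino recovers the binding of compound 2 remains open. Also open, on these data alone, is what the methyl and defined stereocentre of 2-methylpyrrolidin-1-yl contribute, which unsubstituted pyrrolidin-1-yl or the opposite enantiomer would address.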